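The source may hold more compounds than are shown below. What is called first, only, known or untested is meant among the compounds shown, and "the series" means these compounds.

Going by these compounds, in a functional assay on K562 cells (Homo sapiens) for inhibition, read by sulforhodamine B assay, with a stated time of 48 h (a lower number here means a stronger inhibitor of growth, a higher number a weaker inhibitor of growth), compound 2 `COc1ccc(/C=C/C2(C)C=CC(=O)O2)c(OC)c1` gives only a limit, > 1000000 nM, so its true position is unknown. Compound 1 `CC1(/C=C/c2ccc(F)cc2)C=CC(=O)O1` also gives only a limit, > 1000000 nM. Compound 3 `COc1ccccc1/C=C/C1(C)C=CC(=O)O1` gives an actual number, 860000 nM. The small series therefore sits largely at the limit of > 1000000 nM in this assay, at which 2 of the 3 values shown sit.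

Compound 4 `COc1ccc(/C=C/C2(C)C=CC(=O)O2)cc1` differs from compound 2 by hydrogen in place of methoxy on an aromatic carbon. This puts hydrogen in place of methoxy on an aromatic carbon, ortho to a group of 9 heavy atoms and meta to a methoxy group. The closest measured precedent is the same kind of swap at the other methoxy group of compound 2, which gives an at least 1.1-fold lower number from compound 2 to compound 3 (0.06 log units; that floor lies within the scatter). As compound 2 is only a limit, that step is a floor and not a true size.

Going by compound 3 at 860000 nM, a modest move to a lower number is expected, or none beyond the scatter. The expected step is an at least 1.2-fold lower number from compound 2 to compound 4 (0.09 log units; that floor lies within the scatter). Compound 4 is estimated at 800000 nM, with an expected range of 350000 nM to 1500000 nM.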

Compound 4, concentration for total growth inhibition: > 1000000 nM
Compound 4 ended at the assay's limit; the forecaster's own chance of this, stated with the estimate: 45%; middle value at least 1.2-fold (0.09 log units) away from the limit.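

Compound 4 gives only a limit, so the steps to it from compound 2 and from compound 1 cannot be read: the limit of > 1000000 nM in this assay, at which 3 of the 4 values shown sit.

The compounds shown leave open where compound 1, compound 2 and compound 4 truly lie, and so whether swapping either methoxy group for hydrogen changes growth inhibition at all.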